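Rhodanine dienes: aryl-methoxy variation on the shared core

The compounds below may be only part of what the source reports. "The series", "measured", "known", "first", "only" and "open" are said of these compounds alone.

Measured compounds:
compound 1 `O=C1NC(=S)S/C1=C\C=C\c1ccccc1OCc1ccccc1C(F)(F)F`, 80% in a functional assay on DLD-1 cells (Homo sapiens), read by microscopy and crystal violet staining, with a stated time of 20 h, tested at 10 ug/mL; on this read-out lower numbers stand for less inhibition and higher numbers for more inhibition at the one concentration tested (going by the name of the read-out)
compound 2 `O=C1NC(=S)S/C1=C\C=C\c1ccccc1OS(=O)(=O)c1ccccc1`, 80% in this assay
compound 3 `O=C1NC(=S)S/C1=C\C=C\c1ccccc1OCc1ccccc1`, 65% in this assay

Compound 3 stands lowest of the three numbers. Among the measured compounds shown here, its nearest neighbour is compound 1, and the only single-place step recorded, a number 15 percentage points lower from compound 1 to compound 3 (beyond the scatter), is a change of hydrogen in place of trifluoromethyl on an aromatic carbon. Compound 2 is separated from compound 3 by the same gap, but it differs in more than one place, so only its value is stated here.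

Compound 4 `O=C1NC(=S)S/C1=C\C=C\c1ccccc1OCc1ccncc1` has not been measured. It differs from compound 3 as follows: pyridin-4-yl in place of phenyl on a saturated chain carbon bound to an oxygen on an aromatic ring. For the measured compounds named here, no measured step on this series bears on this change; the one recorded step, from compound 1 to compound 3, concerns a substituent on the aromatic ring of the benzyloxy group, not the exchange of that ring for a pyridin-4-yl ring. Going by the values given here, with no step of the same kind to draw on, the expectation is that the change from compound 3 to compound 4 is no change at the digits printed from compound 3 to compound 4 (within the scatter), that is, nothing beyond the scatter. Compound 4 is therefore estimated at 65%, with a range from 50% to 80%.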

Compound 4, a percentage reported as inhibition, at one concentration (the size of the read-out at that concentration, not a potency): 62%
Compound 4: middle estimate off by 3 percentage points, on the high side; measured number inside the range.
By their numbers in this assay, from the lowest: compounds 4 and 3 (each within the scatter of the next); then compounds 1 and 2 (each within the scatter of the next).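

In this assay, pyridin-4-yl in place of phenyl on a saturated chain carbon bound to an oxygen on an aromatic ring gives a number 3 percentage points lower from compound 3 to compound 4 (within the scatter), so at the one concentration tested this place takes a ring nitrogen, and with it one hydrogen-bond acceptor by count, with no readable difference. The earlier compounds shown here showed only a substituent change on this ring, hydrogen in place of trifluoromethyl, which gave a number 15 percentage points lower from compound 1 to compound 3 (beyond the scatter) and lay beyond the scatter, whereas this exchange of the ring itself lies within it. Nothing on hand bears on what lies behind either step.

Still open, on these data alone, is whether trifluoromethyl on the pyridin-4-yl ring would repeat the step seen on the phenyl ring, and whether this place keeps its number with a saturated piperidine ring, a carboxylic acid or a longer chain such as phenethoxy in place of the benzyloxy group. Also open is how these percentages at a single concentration relate to potency, since none of the numbers shown comes from a concentration series.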